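The source may hold more compounds than are shown below. What is called first, only, known or untested is meant among the compounds shown, and "the series" means these compounds.

Compound 1 `COc1cc(C(=O)c2cn(-c3ccccc3C)cc2-c2ccccc2)cc(OC)c1OC` is the starting point. In a functional assay on MCF7 cells (Homo sapiens) for cytotoxicity, read by MTT assay, with a stated time of 96 h (a lower number here means a stronger inhibitor, a higher number a weaker inhibitor), compound 1 gives 2200 nM, the highest number among the three measured compounds; compound 2 `COc1cc(C(=O)c2cn(-c3cccc(Br)c3)cc2-c2ccccc2)cc(OC)c1OC` gives 78 nM and compound 3 `COc1cc(C(=O)c2cn(-c3ccc(Br)cc3)cc2-c2ccccc2)cc(OC)c1OC` gives 20 nM. The change to compound 4 `COc1ccc(-n2cc(C(=O)c3cc(OC)c(OC)c(OC)c3)c(-c3ccccc3)c2)cc1` is 4-methoxyphenyl in place of 2-methylphenyl on an aromatic nitrogen. Among the measured compounds shown here, two measured steps bear on it, both replacing 2-methylphenyl on the aromatic nitrogen with another substituted phenyl: a 28-fold lower number from compound 1 to compound 2 (1.45 log units; beyond the scatter) and a 110-fold lower number from compound 1 to compound 3 (2.04 log units; beyond the scatter). On these data alone, since 4-methoxyphenyl, like 4-bromophenyl, carries its substituent away from the position of the methyl in compound 1, a large drop in the number is expected, though the bromine-to-methoxy swap itself is untested. Compound 4 is therefore expected to give 60 nM, between 15 nM and 250 nM. This expectation amounts to a 37-fold lower number from compound 1 to compound 4 (1.56 log units; beyond the scatter).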

Compound 4, half-maximal inhibitory concentration: 120 nM
For compound 4 the middle estimate is 2.0-fold (0.30 log units) below the measured one, and the stated range covers the measured number.
By their numbers in this assay, from the lowest: compound 3; then compounds 2 and 4 (each within the scatter of the next); then compound 1.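

In this assay, the large drop is not limited to bromine-bearing groups: 4-methoxyphenyl in place of 2-methylphenyl gives an 18-fold lower number from compound 1 to compound 4 (1.26 log units; beyond the scatter). The choice of group at this nitrogen still matters, as methoxy in place of bromo on 4-bromophenyl gives a 6.0-fold higher number from compound 3 to compound 4 (0.78 log units; beyond the scatter). Meanwhile, 4-methoxyphenyl in place of 3-bromophenyl gives a 1.5-fold higher number from compound 2 to compound 4 (0.19 log units; within the scatter), so those two groups cannot be told apart here. Nothing available explains these differences. On these data alone, it remains open how a phenyl carrying an amine, a carboxylic acid or a longer alkoxy chain would behave at this nitrogen.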